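Trading dimethylcarbamoyl for dimethylsulfamoyl on compound 2

The source may hold more compounds than are shown below. What is called first, only, known or untested is meant among the compounds shown, and "the series" means these compounds.

In an in vitro ADME assay on microsomes from liver (Homo sapiens) for metabolic stability (a higher number here means faster removal of the compound, a lower number slower removal), compound 1 (`Cc1cnc(NC(=O)c2cc(Oc3cnc(C(=O)N(C)C)cn3)c3cn(C)nc3c2)cn1`) gives < 8.5 mL/min/kg as a limit of the assay and not a number. Within the data shown here, compound 2 (`Cc1cnc(NC(=O)c2cc(Oc3ccc(C(=O)N(C)C)cc3)c3cn(C)nc3c2)cn1`) gives 12.3 mL/min/kg and so holds the only exact number so far. Compound 3 (`Cc1cnc(NC(=O)c2cc(Oc3ccc(S(=O)(=O)N(C)C)cc3)c3cn(C)nc3c2)cn1`) has dimethylsulfamoyl in place of dimethylcarbamoyl on an aromatic carbon. Among the measured compounds shown here, no measured pair shows this exchange, so the expected step (a 1.1-fold higher number from compound 2 to compound 3 (0.02 log units; within the scatter)) stays within the usual scatter, with no direction favoured. For compound 3 the estimated clearance is 13 mL/min/kg (expected range 8.5 mL/min/kg to 22 mL/min/kg).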

Compound 3, clearance: < 8 mL/min/kg
Compound 3 was reported as a limit; the forecaster's own chance of this, stated with the estimate: 20%; at least 1.6-fold (0.21 log units) between middle value and limit.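

In this assay, among these compounds, the first exchange that can be read at this place gives an at least 1.5-fold lower number from compound 2 to compound 3 (0.18 log units; that floor lies within the scatter). Dimethylsulfamoyl therefore shows no sign of faster removal than dimethylcarbamoyl, although this floor alone does not separate the two compounds. Compound 3 gives a limit and not a number, so the full size of the step stays unknown because of where it sits in the assay: the limit of < 8 mL/min/kg in this assay, at which 1 of the 3 values shown sits.

On these data alone, whether a carboxylic acid or an amine at this place would keep removal this slow remains open. So does whether the same exchange would give a similar step on the ring of compound 1.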